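Methoxy in Place of Fluoro: What to Expect

A few compounds are considered here, and "the series" means these few. Any claim that something is new, unique, unknown or untested is made for them only; others in the source may bear on it.

Compound 1 `O=C(O)CCc1cccc2c1B(O)OC2` carries a free carboxylic acid on the shared core. In a functional assay on MDA-MB-231 cells (Homo sapiens) for antiproliferative activity, read by MTT assay, with a stated time of 72 h (a lower number here means a stronger inhibitor, a higher number a weaker inhibitor), compound 1 reaches only a limit, > 100000 nM. Among the measured compounds shown here, compound 2 `O=C(CCc1cccc2c1B(O)OC2)Nc1ccc(F)cc1`, in which that acid is turned into an amide of a fluoro-bearing aniline, gives 440 nM in this assay; this is the only plain number so far. The other value shown, that of compound 1, is a limit (the limit of > 100000 nM in this assay, at which 1 of the 2 values shown sits). Compound 3 `COc1ccc(NC(=O)CCc2cccc3c2B(O)OC3)cc1` differs from compound 2 by methoxy in place of fluoro on an aromatic carbon. For the measured compounds named here, no measured step exists to lean on, so the expected change is a 1.1-fold higher number from compound 2 to compound 3 (0.06 log units; within the scatter), within the usual scatter. Compound 3 is therefore estimated at 500 nM, with a range of 200 nM to 1500 nM.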

Compound 3, half-maximal inhibitory concentration: 850 nM
The estimate for compound 3 lay 1.7-fold (0.23 log units) below the measured number, within the range that was stated.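

In this assay methoxy in place of fluoro, on an aromatic carbon para to a large group, gives a 1.9-fold higher number from compound 2 to compound 3 (0.29 log units; within the scatter) and so leaves the two compounds indistinguishable. Among the compounds shown here, this is the first measured comparison at this position, and it shows that the activity of compound 2 does not depend on fluoro alone, since a larger group with one hydrogen-bond acceptor reads the same. On these data alone, whether an amine, a carboxylic acid or a trifluoromethyl at this place would also read alike stays open. Nothing shown explains why fluoro and methoxy read alike here.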